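Swapping the lactam for a dioxolane on the core

This account rests on a few compounds, and the source may have more. Where it says the series, first, only, none or still open, it means among the compounds named here.

In an assay on microsomes from liver for inhibition of sterol O-acyltransferase 1 (Rattus norvegicus) (a lower number here means a stronger inhibitor, a higher number a weaker inhibitor), compound 3 `O=C1CCC(CSc2nc(-c3ccccc3)c(-c3ccccc3)[nH]2)N1` gives 360 nM, the highest of the three numbers. Compound 1 `C[C@@]1(O)CC(=O)OC(CSc2nc(-c3ccccc3)c(-c3ccccc3)[nH]2)C1` gives 170 nM in this assay and compound 2 `CO[C@H]1C[C@H](O)C[C@@H](CSc2nc(-c3ccccc3)c(-c3ccccc3)[nH]2)O1` gives 90 nM; the two differ by a 1.9-fold lower number from compound 1 to compound 2 (0.28 log units; within the scatter). Both bear on the question, since a 2.1-fold higher number from compound 1 to compound 3 (0.33 log units; beyond the scatter) and a 4.0-fold higher number from compound 2 to compound 3 (0.60 log units; beyond the scatter) show that the 5-oxopyrrolidin-2-yl group on the saturated chain carbon bound to a sulfur gives a weaker inhibitor than either six-membered ring bearing oxygen. Compound 4 `c1ccc(-c2nc(SCC3OCCO3)[nH]c2-c2ccccc2)cc1` differs from compound 3 as follows: 1,3-dioxolan-2-yl in place of 5-oxopyrrolidin-2-yl on a saturated chain carbon bound to a sulfur. Within the data shown here, no measured step covers this change itself, so its direction is uncertain. As the 1,3-dioxolan-2-yl group is again a small five-membered ring, the number for compound 4 is expected to stay near compound 3, with a step of a 1.2-fold lower number from compound 3 to compound 4 (0.08 log units; within the scatter) meaning little beyond the scatter. Compound 4 is therefore estimated at 300 nM, within a range from 120 nM to 800 nM.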

Compound 4, half-maximal inhibitory concentration: 530 nM
Compound 4: the middle estimate sits 1.8-fold (0.25 log units) below what was measured; low and high end bracket the measured number.
By their numbers in this assay, from the lowest: compounds 2 and 1 (each within the scatter of the next); then compounds 3 and 4 (each within the scatter of the next).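

In this assay, putting 1,3-dioxolan-2-yl in place of 5-oxopyrrolidin-2-yl on a saturated chain carbon bound to a sulfur gives a 1.5-fold higher number from compound 3 to compound 4 (0.17 log units; within the scatter), so these two five-membered rings cannot be told apart here, even though the entering group has 0 hydrogen-bond donors and the leaving group has 1. The gap to the six-membered rings now appears with a second five-membered ring, at a 5.9-fold higher number from compound 2 to compound 4 (0.77 log units; beyond the scatter) and a 3.1-fold higher number from compound 1 to compound 4 (0.49 log units; beyond the scatter), and none of the four compounds goes against it. Nothing measured here explains these steps.

The compounds shown leave open whether ring size itself or the substituents on the six-membered rings account for this gap. A bare 1,3-dioxan-2-yl group would address that question, while an open-chain amine at the same place remains untested among these compounds.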